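Removing the bromoacrylamide from compound 1: an aniline analogue

The compounds below may be only part of what the source reports. "The series", "measured", "known", "first", "only" and "open" are said of these compounds alone.

Compound 1 `C=C(Br)C(=O)Nc1cccc(-c2cn3nc(-c4ccc(F)cc4)sc3n2)c1` sits in the middle of the three measured compounds in a functional assay on L1210 cells (Mus musculus) for inhibition, read by cell counting, with a stated time of 2 days (a lower number here means a stronger inhibitor, a higher number a weaker inhibitor), giving 250 nM. Compound 3 `C=C(Br)C(=O)Nc1cccc(-c2cn3nc(-c4cccs4)sc3n2)c1` gives 170 nM, and the step of a 1.5-fold lower number from compound 1 to compound 3 (0.17 log units; within the scatter) lies within the scatter. Compound 2 `C=C(Br)C(=O)Nc1cccc(-c2cn3nc(-c4cccc(OC)c4)sc3n2)c1` gives 580 nM, so the step of a 2.3-fold higher number from compound 1 to compound 2 (0.37 log units; beyond the scatter) is modest. Compound 4 `Nc1cccc(-c2cn3nc(-c4ccc(F)cc4)sc3n2)c1` differs from compound 1 by hydrogen in place of (1-bromoethenyl)carbonyl on a nitrogen on an aromatic ring. Within the data shown here, none of the measured steps touches this nitrogen; all three vary the aromatic group on the opposite side of the shared core, so they give no direct guide to the size of this change. The expectation is nonetheless a higher number, a step of a 12-fold higher number from compound 1 to compound 4 (1.08 log units; beyond the scatter), with wide uncertainty. Compound 4 is estimated at 3000 nM, within the range 400 nM to 25000 nM.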

Compound 4, half-maximal inhibitory concentration: >= 250000 nM
Compound 4: only a limit was reported; the forecaster's own chance of this, stated with the estimate: 15%; at least 83-fold (1.92 log units) between middle value and limit.
By their numbers in this assay, from the lowest: compounds 3 and 1 (each within the scatter of the next); then compound 2. At a limit, above all of these: compound 4.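

In this assay compound 4 gives only >= 250000 nM, which is a limit and not a number. Replacing the (1-bromoethenyl)carbonyl on the nitrogen with hydrogen produces an at least 1000-fold higher number from compound 1 to compound 4 (3.00 log units; beyond the scatter). Among these compounds, this step is far larger than any among the earlier compounds, which changed only the aromatic group elsewhere on the shared core.

On these data alone, it remains open whether an acetyl or an unbrominated acryloyl group on this nitrogen would retain the number of compound 1. Also open, as far as these compounds go, is whether the thiophen-2-yl and 3-methoxyphenyl series would respond to this change in the same way.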